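The compounds below may be only part of what the source reports. "The series", "measured", "known", "first", "only" and "open" are said of these compounds alone.

In a functional assay on P388 cells (Mus musculus) for antiproliferative activity, read by colorimetric assay and MTT assay (a lower number here means a stronger inhibitor, a higher number a weaker inhibitor), compound 1 (`Nc1ccc(S(=O)(=O)Nc2ccc(F)c3c(Cl)c[nH]c23)cc1`) gives 0.51 ug/mL and compound 2 (`Nc1ccc(S(=O)(=O)Nc2ccc(Br)c3c(Cl)c[nH]c23)cc1`) gives 0.64 ug/mL on the same read-out, so compound 2 stands within the scatter of compound 1 and is not separated from it. Compound 3 (`Cc1ccc(NS(=O)(=O)c2ccc(N)cc2)c2[nH]cc(Cl)c12`) differs from compound 2 by methyl in place of bromo on an aromatic carbon. Among the measured compounds shown here, one measured step bears on this change, bromo in place of fluoro on an aromatic carbon, and it was small, with a 1.3-fold higher number from compound 1 to compound 2 (0.10 log units; within the scatter) as its size. For the measured compounds named here, no measured compound yet carries methyl, so this evidence is only indirect. On that basis, no step beyond the scatter is expected in this assay for this exchange. The estimate amounts to an expected 1.1-fold lower number from compound 2 to compound 3 (0.03 log units; within the scatter) and no more. For compound 3 the estimate is 0.6 ug/mL with an expected range of 0.25 ug/mL to 1.4 ug/mL for the half-maximal inhibitory concentration.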

Compound 3, half-maximal inhibitory concentration: 0.37 ug/mL
Compound 3: the middle estimate sits 1.6-fold (0.21 log units) above what was measured; low and high end bracket the measured number.
By their numbers in this assay, from the lowest: compounds 3, 1 and 2 (each within the scatter of the next).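

In this assay, the exchange of bromo for methyl gives a 1.7-fold lower number from compound 2 to compound 3 (0.24 log units; within the scatter), and the exchange of fluoro for methyl gives a 1.4-fold lower number from compound 1 to compound 3 (0.14 log units; within the scatter). The earlier compounds shown here compared only two halogens at this position, whereas compound 3 shows that a methyl group, which is not a halogen, also stays within the scatter of both, so the three groups are not separated here. The data offer no measured basis for explaining why these groups read alike.

From the compounds shown here alone, it remains open whether an amine, a carboxylic acid or a methoxy group on this aromatic carbon would give a step beyond the scatter. Nor do these compounds show whether a longer chain, such as propyl or butyl, would stay as close to compound 3 as the smaller groups do.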